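Dichloro substitution on the terminal phenyl of compound 3

The source may report more compounds than this note shows. Statements on the series, on what has been measured and on what is new or still open speak of the compounds shown alone.

Compound 3 `O=C(CCCc1ccccc1)Nc1nc2ccccc2c(=O)s1` sits at the limit in an assay on CHO cells for displacement of a labelled ligand from adenosine receptor A2b (Homo sapiens), read by scintillation counting, with a stated time of 75 min; on this read-out higher numbers stand for weaker inhibition and lower numbers for stronger inhibition: compound 3 gives > 1000 nM, which is a limit of the assay and not a number. Compound 2 `O=C(CCCc1ccccc1)Nc1nc2ccc(Cl)cc2c(=O)s1` likewise returns only a limit in this assay, > 1000 nM. Compound 1 `COc1cccc(CCC(=O)Nc2nc3ccccc3c(=O)s2)c1` gives 225 nM in this assay. Within the data shown here, the one readable step is an at least 4.4-fold higher number from compound 1 to compound 3 (0.64 log units; beyond the scatter). The step that the two limits leave unreadable from compound 2 to compound 3 cannot be sized, since both values sit at the limit of > 1000 nM in this assay, at which 2 of the 3 values shown sit. Compound 4 `O=C(CCCc1ccc(Cl)c(Cl)c1)Nc1nc2ccccc2c(=O)s1` differs from compound 3 by 3,4-dichlorophenyl in place of phenyl on a saturated chain carbon, three bonds along the chain from a carbonyl carbon. Neither measured step concerns this phenyl: the first changes the aryl group together with the chain it sits on, the second changes the core. Among the measured compounds shown here, no step bears directly on the change, so the expectation rests on compound 3 alone. Compound 4 is expected to remain near the same limit. The expected step is a step that the limit leaves unreadable from compound 3 to compound 4, within the scatter. The estimate for compound 4 is 1500 nM, between 300 nM and 6000 nM.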

Compound 4, inhibition constant: > 1000 nM
Compound 4: no number, only a limit; the forecaster's own chance of this, stated with the estimate: 60%; the middle value lies beyond the limit too.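

Among these compounds, compound 3 and compound 4 both return only a limit in this assay, so no step between them can be read: the limit of > 1000 nM in this assay, at which 3 of the 4 values shown sit. The compounds shown leave open whether 3,4-dichlorophenyl in place of phenyl changes the inhibition constant at all.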